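A few compounds are considered here, and "the series" means these few. Any claim that something is new, unique, unknown or untested is made for them only; others in the source may bear on it.

Measured so far in an assay on HEK293 cells for positive allosteric modulation of metabotropic glutamate receptor 2 (Rattus norvegicus), read by thallium flux, with a stated time of 2.5 min; on this read-out higher numbers stand for an effect only at larger amounts of compound and lower numbers for an effect already at smaller amounts:
compound 1 `COc1cc(C(=O)O)ccc1OCCCCOc1ccc(C(=O)C(C)C)c(O)c1C` — 113 nM
compound 2 `COc1cc(C(=O)O)ccc1OCCCCOc1ccc(C(=O)CC(C)(C)C)c(O)c1C` — 47 nM
compound 3 `COc1cc(C(=O)O)ccc1OCCCCOc1ccc(C(C)=O)c(O)c1C` — 161 nM

Compound 3 gives the highest of the three numbers; to compound 1 it stands within the scatter, while a 3.4-fold higher number from compound 2 to compound 3 (0.53 log units; beyond the scatter) lies beyond it. Compound 4 `CCC(=O)c1ccc(OCCCCOc2ccc(C(=O)O)cc2OC)c(C)c1O` carries the change (methyl in place of hydrogen on a saturated chain carbon bound to a carbonyl carbon). The step that bears on it most directly is the reverse of a 3.4-fold higher number from compound 2 to compound 3 (0.53 log units; beyond the scatter), where a larger group on that chain carbon went with a lower number; a 1.4-fold higher number from compound 1 to compound 3 (0.15 log units; within the scatter), on the neighbouring carbonyl carbon, stayed within the scatter, and a 2.4-fold lower number from compound 1 to compound 2 (0.38 log units; beyond the scatter) lowered the number modestly. A single methyl is a smaller addition than either, so only a slight drop, within the scatter, is expected: a 1.3-fold lower number from compound 3 to compound 4 (0.13 log units; within the scatter). For compound 4 in this assay the estimate is 120 nM, range 60 nM to 240 nM.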

Compound 4, half-maximal effective concentration: 114 nM
Compound 4: middle estimate off by 1.1-fold (0.02 log units), on the high side, within the range that was stated.
By their numbers in this assay, from the lowest: compound 2; then compounds 1, 4 and 3 (each within the scatter of the next).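

In this assay, methyl in place of hydrogen on the saturated chain carbon bound to a carbonyl carbon stays within the scatter (a 1.4-fold lower number from compound 3 to compound 4 (0.15 log units; within the scatter)). Going on from ethyl to isopropyl also stays within it (a 1.0-fold higher number from compound 1 to compound 4 (0.00 log units; within the scatter)), so compounds 1, 3 and 4 cannot be told apart. Only the tert-butyl of compound 2 separates from this group, beyond the scatter (a 2.4-fold higher number from compound 2 to compound 4 (0.38 log units; beyond the scatter)).

As far as these compounds go, whether a longer chain, a ring or an amine at this place would follow compound 2 remains open. Nothing shown gives a reason for this pattern.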